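Working notes on the aryl variation: toward compound 4

The source may hold more compounds than are shown below. What is called first, only, known or untested is meant among the compounds shown, and "the series" means these compounds.

Three analogues share one core and differ only in the aryl group attached to it. Compound 1 `C=Cc1ccc(-c2cc(C)c3ncc(CSCCc4ccccc4)n3c2)cc1` gives 14 ug/mL in an ADME assay on HEL cells (Homo sapiens) for cytotoxicity, with a stated time of 3 days; a higher number here means that more compound is tolerated, a lower number that less compound is tolerated. Compound 2 `Cc1cc(-c2ccc3[nH]ccc3c2)cn2c(CSCCc3ccccc3)cnc12` gives 26 ug/mL in this assay, and compound 3 `Cc1cc(-c2ccoc2)cn2c(CSCCc3ccccc3)cnc12` gives 12 ug/mL. Compound 2 carries the highest number of the three: the step of a 1.9-fold higher number from compound 1 to compound 2 (0.27 log units; within the scatter) stays within the scatter, whereas a 2.2-fold lower number from compound 2 to compound 3 (0.34 log units; beyond the scatter) is a modest step beyond it, and a 1.2-fold lower number from compound 1 to compound 3 (0.07 log units; within the scatter) lies within the scatter.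

Compound 4 `Cc1cc(Sc2ccc(Cl)cc2)cn2c(CSCCc3ccccc3)cnc12` is unmeasured and differs from compound 2 in one place: (4-chlorophenyl)sulfanyl in place of 1H-indol-5-yl on an aromatic carbon. The steps that touch 1H-indol-5-yl bear on this change: the one away from it, a 2.2-fold lower number from compound 2 to compound 3 (0.34 log units; beyond the scatter), was modest and downward, while the one toward it, a 1.9-fold higher number from compound 1 to compound 2 (0.27 log units; within the scatter), stayed within the scatter. For the measured compounds named here, no measured step introduces a (4-chlorophenyl)sulfanyl group, so the change is loosely anchored. A small downward step is expected, probably within the scatter, a 1.4-fold lower number from compound 2 to compound 4 (0.16 log units; within the scatter), because a 2.2-fold lower number from compound 2 to compound 3 (0.34 log units; beyond the scatter) was downward though modest. The estimate for compound 4 in this assay is 18 ug/mL, with a range from 8 ug/mL to 35 ug/mL.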

Compound 4, half-maximal cytotoxic concentration: 14 ug/mL
Compound 4: middle estimate off by 1.3-fold (0.11 log units), on the high side; the measured number falls inside the stated range.
By their numbers in this assay, from the lowest: compounds 3, 1, 4 and 2 (each within the scatter of the next, the first and the last beyond it).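

In this assay, for the compounds shown here, the (4-chlorophenyl)sulfanyl group, the first group with a sulfur atom on this aromatic carbon, gives a 1.9-fold lower number from compound 2 to compound 4 (0.27 log units; within the scatter) and so stays within the scatter of the group with the highest number. The comparisons with the other two groups also stay within the scatter, with a 1.2-fold higher number from compound 3 to compound 4 (0.07 log units; within the scatter) and with no change at the digits printed from compound 1 to compound 4 (within the scatter) as well. Compound 4 therefore joins compound 1 and compound 3 in a band that cannot be ordered, and nothing available explains these cytotoxicity values.

From the compounds shown here alone, whether the sulfur link matters on its own remains open, since a 4-chlorophenyl group joined directly to this carbon would be needed to separate it from the chlorophenyl ring. Also open, going by these compounds, is whether an amine or a carboxylic acid here would move the number beyond the scatter.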